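Widening the Tail Ring of Compound 3

The source may report more compounds than this note shows. Statements on the series, on what has been measured and on what is new or still open speak of the compounds shown alone.

Of the compounds shown here, three that share one core have been measured in a functional assay for antagonist activity at C-C chemokine receptor type 4 (Homo sapiens), read by GTPgammaS binding; on this read-out lower numbers stand for stronger inhibition and higher numbers for weaker inhibition. Compound 1 `COc1cc2nc(N3CCC(N4CCCC4)CC3)nc(Nc3ccc(F)c(F)c3)c2cc1OC` gives 25 nM. Compound 2 `COc1cc2nc(N3CCC(N4CCCC4)CC3)nc(Nc3cccc(Br)c3)c2cc1OC` gives 220 nM. Compound 3 `COc1cc2nc(N3CCCN(CCN4CCCC4)CC3)nc(Nc3ccc(Cl)cc3)c2cc1OC` gives 150 nM. Set beside compound 2, the number for compound 3 lies within the usual scatter; set beside compound 1, compound 3 shows the higher number of the two, so compound 3 sits with compound 2 rather than with compound 1.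

Compound 4 `COc1cc2nc(N3CCCN(CCN4CCCCC4)CC3)nc(Nc3ccc(Cl)cc3)c2cc1OC` has not yet been measured. It differs from compound 3 in one place: piperidin-1-yl in place of pyrrolidin-1-yl on a saturated chain carbon, two bonds along the chain from an amine nitrogen in a ring. For the measured compounds named here, the only step measured so far between two compounds that differ in one place is the swap of 3-bromophenyl for 3,4-difluorophenyl on a nitrogen on an aromatic ring, which gives an 8.8-fold higher number from compound 1 to compound 2 (0.94 log units; beyond the scatter). That step changes the aryl group, not the saturated tail, so it does not bear on the change from compound 3 to compound 4. With no measured guide for this part of the structure, the expectation is a step of no change at the digits printed from compound 3 to compound 4 (within the scatter), that is, no change beyond the scatter. Compound 4 is therefore expected to give about 150 nM, with a range from 50 nM to 450 nM.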

Compound 4, half-maximal inhibitory concentration: 130 nM
Compound 4: middle estimate off by 1.2-fold (0.06 log units), on the high side; measured number inside the range.
By their numbers in this assay, from the lowest: compound 1; then compounds 4, 3 and 2 (each within the scatter of the next).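

In this assay, the step from pyrrolidin-1-yl to piperidin-1-yl gives a 1.2-fold lower number from compound 3 to compound 4 (0.06 log units; within the scatter), so the two compounds cannot be told apart on this read-out. For the compounds shown here, this is the first measured step in the saturated tail, and it shows that, at this saturated chain carbon, a six-membered ring can stand in place of a five-membered one without moving the number beyond the scatter. Going by these compounds alone, the only other measured step, the swap on the aryl group that gives an 8.8-fold higher number from compound 1 to compound 2 (0.94 log units; beyond the scatter), lies beyond the scatter, though that one change in each part of the molecule is too little to rank the two parts in general. No measurement available here explains why the two rings read alike.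

What the compounds shown leave open is whether the tail needs a saturated ring at all, or whether a morpholine ring, which carries an oxygen atom, an open dimethylamino group or a longer chain leading to the ring would read the same. They also leave open whether this ring swap would read the same with a 3,4-difluorophenyl group in place of the aryl group shared by compound 3 and compound 4.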